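The compounds below may be only part of what the source reports. "The series", "measured", "known", "first", "only" and "open" are said of these compounds alone.

Compound 3 `COc1ccc(-n2c(S[C@H](C)C(=O)Nc3ccc(C)cc3Cl)nc3ccccc32)cc1`: > 75000 nM
Compound 1 `COc1ccc(-n2c([S+]([O-])C(C)C(=O)Nc3ccc(C)cc3Cl)nc3ccccc32)cc1`: > 75000 nM
Compound 2 `CCOc1ccc(-n2c(SC(C)C(=O)Nc3ncc(Cl)cc3Cl)nc3ccccc32)cc1`: 18500 nM

In an ADME assay on Vero cells (Chlorocebus sabaeus) for cytotoxicity, read by MTT assay, with a stated time of 24 h (a lower number here means that less compound is tolerated, a higher number that more compound is tolerated), compound 3 gives > 75000 nM, which is a limit of the measurement rather than a number. Compound 1 likewise reaches a limit, > 75000 nM. Compound 2 gives 18500 nM, a real number. Compound 3 therefore stands at the limit of > 75000 nM in this assay, at which 2 of the 3 values shown sit, the tolerated end of what was seen. Compound 4 `COc1ccc(-n2c(SC(C)C(=O)Nc3ccc(C)cc3Cl)nc3ccccc32)cc1` is still to be measured. (the two compounds have the same atoms and bonds; at least one stereo element is drawn with a configuration in one of them and without one in the other: 1 of 1 stereo elements differ; a stereocentre at a saturated chain carbon is drawn R in compound 3 and without a configuration in compound 4). Within the data shown here, no step between measured compounds is available to lean on; since the change touches no atom or bond, no movement beyond the usual scatter is expected in this assay, in either direction. Compound 4 is expected to give 75000 nM, between 45000 nM and 150000 nM, which means an expected step of a number no higher from compound 3 to compound 4 (the limit leaves the size open).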

Compound 4, half-maximal cytotoxic concentration: > 75000 nM
Compound 4 gave a limit, no number (the forecaster's own chance of this, stated with the estimate: 80%); the middle value lies on the limit itself.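

Compound 3 and compound 4 both end at a limit in this assay, not at a number, so no step between them can be read: the limit of > 75000 nM in this assay, at which 3 of the 4 values shown sit.

The compounds shown leave open whether the configuration at the stereocentre changes how much compound the cells tolerate.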